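Changing the Amine Ring at the End of a Chain

The compounds below may be only part of what the source reports. "The series", "measured", "known", "first", "only" and "open" are said of these compounds alone.

Of the compounds shown here, three built on one shared core have been measured in a functional assay on U-87MG ATCC cells (Homo sapiens) for inhibition, read by MTT assay, with a stated time of 72 h; on this read-out higher numbers stand for weaker inhibition and lower numbers for stronger inhibition. Compound 1 `COc1cc2c(Oc3ccc(NC(=O)c4nn(-c5ccccc5)c(=O)cc4C)cc3F)ccnc2cc1OCCCN1CCN(C)CC1` gives 2120 nM. Compound 2 `COc1cc2c(Oc3ccc(NC(=O)c4nn(-c5cccc(F)c5)c(=O)cc4C)cc3F)ccnc2cc1OCCCN1CCCC1` gives 1700 nM. Compound 3 `COc1cc2c(Oc3ccc(NC(=O)c4nn(-c5cccc(F)c5)c(=O)cc4C)cc3F)ccnc2cc1OCCCN1CCC(C)CC1` gives 1800 nM, the second highest of the three numbers, nearest to compound 2 and furthest from compound 1, with both gaps inside the scatter. Compound 4 `COc1cc2c(Oc3ccc(NC(=O)c4nn(-c5cccc(F)c5)c(=O)cc4C)cc3F)ccnc2cc1OCCCN1CCN(C)CC1` differs from compound 3 by 4-methylpiperazin-1-yl in place of 4-methylpiperidin-1-yl on a saturated chain carbon, three bonds along the chain from an oxygen on an aromatic ring. Going by the values given here, no measured step covers this exact exchange. Compound 1 carries the same 4-methylpiperazin-1-yl group and gives 2120 nM, but it also differs from compound 4 in a second place, so it serves only as a loose pointer. Among the compounds with values here, compound 4 is expected to show a 1.1-fold higher number from compound 3 to compound 4 (0.02 log units; within the scatter), because a 1.1-fold higher number from compound 2 to compound 3 (0.02 log units; within the scatter) is the only measured ring exchange at this place and it stayed within the scatter while all three numbers sit close together. The estimate for compound 4 is therefore 1900 nM, with a range from 1000 nM to 3600 nM.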

Compound 4, half-maximal inhibitory concentration: 1590 nM
Beside the measured number, compound 4's estimate is 1.2-fold (0.08 log units) above it, and the stated range covers the measured number.
By their numbers in this assay, from the lowest: compounds 4, 2, 3 and 1 (each within the scatter of the next).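

In this assay the exchange of 4-methylpiperidin-1-yl for 4-methylpiperazin-1-yl gives a 1.1-fold lower number from compound 3 to compound 4 (0.05 log units; within the scatter) and the exchange of pyrrolidin-1-yl for 4-methylpiperazin-1-yl gives a 1.1-fold lower number from compound 2 to compound 4 (0.03 log units; within the scatter) so three different amine rings at this place on the chain now read alike, whether the ring holds 1 hetero atom or 2. Going by these compounds alone, the same compound also offers the first reading of a second single change: fluoro in place of hydrogen on an aromatic carbon gives a 1.3-fold lower number from compound 1 to compound 4 (0.12 log units; within the scatter) and this exchange, too, stays within the scatter. No measurement shown here accounts for how close these numbers lie.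

Still open, from the compounds shown here alone, is whether an open-chain amine such as dimethylamino or a morpholine ring at the end of the chain would read the same. Also open, going by these compounds, are the effects of a longer chain and of chlorine in place of that fluoro.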